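A larger group in place of chloro

A few compounds are considered here, and "the series" means these few. Any claim that something is new, unique, unknown or untested is made for them only; others in the source may bear on it.

In an ADME assay on a cell-free system (plasma, Rattus norvegicus) for protein binding, compound 1 (`CNc1nccc(N2CC[C@H](NC(=O)Nc3ccc(Cl)c(C(F)(F)F)c3)C2)n1`) gives 99.7%. Going by the values given here, it stands level, within the scatter, with its only measured neighbour, compound 2 (`Nc1nccc(N2CC[C@H](NC(=O)Nc3ccc(Cl)c(C(F)(F)F)c3)C2)n1`), which gives 99.4%. Compound 3 (`CCN1CCN(Cc2ccc(NC(=O)N[C@H]3CCN(c4ccnc(NC)n4)C3)cc2C(F)(F)F)CC1`) differs from compound 1 as follows: (4-ethylpiperazin-1-yl)methyl in place of chloro on an aromatic carbon. The new group, (4-ethylpiperazin-1-yl)methyl, sits ortho to a trifluoromethyl group. Among the compounds with values here, the one measured step, a 2.0-fold higher unbound fraction from compound 1 to compound 2 (0.30 log units; within the scatter), puts hydrogen in place of methyl on a nitrogen on an aromatic ring. It lies elsewhere in the molecule and within the scatter, so it bears only weakly on this change. Within the data shown here, no measured compound shows what replacing chloro does. The expected step, resting only on the size of the change, is a 5.0-fold higher unbound fraction from compound 1 to compound 3 (0.70 log units; beyond the scatter), towards more free compound and beyond the scatter. In this assay, the estimate for compound 3 is 98.5%, with an expected range of 96% to 99.6%.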

Compound 3, plasma protein binding: 84.2%
Estimate against measurement, compound 3: 11-fold (1.02 log units) (unbound fraction) below; the whole stated range lies above it.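

Going by these compounds alone, the position held by chloro, on the six-membered aromatic ring ortho to a trifluoromethyl group and para to a large group, responds strongly in this assay with a 53-fold higher unbound fraction from compound 1 to compound 3 (1.72 log units; beyond the scatter), whereas the only earlier step lay within the scatter. Changing this one group therefore moves a very highly bound compound to one with a clearly larger free share. No evidence on the origin of this step is available.

The entering (4-ethylpiperazin-1-yl)methyl differs from chloro in size, in its ring and in its nitrogen atoms all at once, and the compounds shown do not separate these. As far as these compounds go, whether a smaller dimethylaminomethyl group or a (morpholin-4-yl)methyl group at this place would give a similar step remains open, as does the part played by the ethyl group.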